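The source may hold more compounds than are shown below. What is called first, only, known or untested is meant among the compounds shown, and "the series" means these compounds.

Of the compounds shown here, two with a shared core have been measured in an assay on HEK293 cells for inhibition of Voltage-dependent T-type calcium channel subunit alpha-1G (Homo sapiens), read by fluorescence, tested at 10 uM; on this read-out higher numbers stand for more inhibition at the one concentration tested (going by the name of the read-out) and lower numbers for less inhibition. Compound 1 `CCCc1nc(-c2ccccc2)c(CNCCN2CCN(c3ccc(F)cc3)CC2)o1` gives 54.1%, and compound 2 `CCCc1nc(-c2ccccc2)c(CNCCN2CCN(c3ccccc3)CC2)o1` gives 54.3%. Within the data shown here, the one step between them, a number 0.2 percentage points higher from compound 1 to compound 2 (within the scatter), shows that swapping hydrogen for fluoro on the aromatic ring at the end of the molecule left the read-out essentially unchanged. Among the measured compounds shown here, compound 2 therefore holds the higher of the two numbers so far, but only by a margin that means nothing against the usual scatter.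

Compound 3 `CCCc1nc(-c2ccccc2)c(CNCCN2CCN(c3ccccn3)CC2)o1` differs from compound 2 by pyridin-2-yl in place of phenyl on an amine nitrogen in a ring. For the measured compounds named here, no measured step covers this kind of change: the only step in hand, a number 0.2 percentage points higher from compound 1 to compound 2 (within the scatter), concerns a small substituent on that same ring rather than an exchange of one ring for another, and it was within the scatter. With no evidence pointing either way, the estimated step is a number 4.3 percentage points lower from compound 2 to compound 3 (within the scatter), that is, no change beyond the scatter is expected. Compound 3 is expected to give 50%, with a range from 28% to 70%.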

Compound 3, a percentage reported as inhibition, at one concentration (the size of the read-out at that concentration, not a potency): 48.1%
Beside the measured number, compound 3's estimate is 1.9 percentage points above it, within the range that was stated.
By their numbers in this assay, from the lowest: compounds 3, 1 and 2 (each within the scatter of the next).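

Exchanging the ring itself on this amine nitrogen, rather than only removing a fluoro substituent from it, is a larger change, yet the step for phenyl to pyridin-2-yl is a number 6.2 percentage points lower from compound 2 to compound 3 (within the scatter) in this assay and the step for 4-fluorophenyl to pyridin-2-yl is a number 6 percentage points lower from compound 1 to compound 3 (within the scatter) and so stays just as unresolved. Placing a ring nitrogen, and with it a hydrogen-bond acceptor, into this aromatic ring therefore gives no shift in the read-out that can be told apart from the scatter, so the three aromatic groups shown cannot be ranked here. No other data bear on this result, so nothing can be said about what lies behind it.

The compounds shown leave open whether a group of a different kind on this ring nitrogen, such as a benzyl group, an acetyl group or a saturated cyclohexyl ring, would move the number beyond the scatter. The rest of the molecule is also the same throughout, so the effect of a longer chain in place of the propyl group, or of a carboxylic acid on the phenyl ring of the shared core, remains an open question.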